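Dropping One Methoxy Group: Compound 3 to Compound 4

This account rests on a few compounds, and the source may have more. Where it says the series, first, only, none or still open, it means among the compounds named here.

Three measured compounds set the scene. Compound 1 `COc1ccc(/C=C/C(=O)c2cccc(Br)c2)cc1OC` gives 9430 nM in a functional assay on A549 cells (Homo sapiens) for cytotoxicity, read by sulforhodamine B assay, with a stated time of 48 h; a higher number here means a weaker inhibitor, a lower number a stronger inhibitor. Compound 2 `COc1ccc(/C=C/C(=O)c2cccc(Br)c2)cc1` gives 34200 nM in this assay. The step between them, a 3.6-fold higher number from compound 1 to compound 2 (0.56 log units; beyond the scatter), is hydrogen in place of methoxy on an aromatic carbon. Compound 3 `COc1cc(/C=C/C(=O)c2ccc(N)c(-c3ccc(F)cc3)c2)cc(OC)c1OC` gives 6070 nM in this assay; its number and that of compound 1 lie within the usual scatter of each other, while compound 2 stands beyond it. How the core of compound 3 differs from the core of compound 1 is not broken down here.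

Compound 4 `COc1ccc(/C=C/C(=O)c2ccc(N)c(-c3ccc(F)cc3)c2)cc1OC` has not yet been measured. It differs from compound 3 by hydrogen in place of methoxy on an aromatic carbon. For the measured compounds named here, this is the same kind of change as the one from compound 1 to compound 2, though not the same: in compound 3 the place is also meta to a methoxy group. Going by the values given here, the earlier step, a 3.6-fold higher number from compound 1 to compound 2 (0.56 log units; beyond the scatter), is the only guide. On that basis a step of a 2.5-fold higher number from compound 3 to compound 4 (0.39 log units; beyond the scatter) is expected, with the altered setting around the place leaving the size less certain. Compound 4 is therefore estimated at 15000 nM, within a range from 7000 nM to 35000 nM.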

Compound 4, half-maximal inhibitory concentration: 8630 nM
Estimate against measurement, compound 4: 1.7-fold (0.24 log units) above, within the range that was stated.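

In this assay, the new step is a 1.4-fold higher number from compound 3 to compound 4 (0.15 log units; within the scatter), so on this core the exchange of methoxy for hydrogen gives no change that can be told apart from the scatter. Set beside the earlier step on the core of compound 1, the new step does not differ from it by more than the scatter of two such steps allows: the same change on two cores in this assay, a 3.6-fold higher number (0.56 log units; beyond the scatter) from compound 1 to compound 2 and a 1.4-fold higher number (0.15 log units; within the scatter) from compound 3 to compound 4, 2.6-fold (0.41 log units) apart, within the scatter of two such steps The two cores therefore give no sign that the change behaves differently from one to the other, but this does not show that it carries over with a fixed size, as one step lies beyond the scatter, the other lies within it, and only two pairs are available.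

The compounds shown leave open what happens when the methoxy group gives way to something other than hydrogen, such as a hydroxy group or a fluorine atom, on either core. They also leave open whether a longer chain, such as an ethoxy group, would change the number in this assay.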